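Deacetylation of a Glycoside Followed in a Cell Growth Assay

This account rests on a few compounds, and the source may have more. Where it says the series, first, only, none or still open, it means among the compounds named here.

Measured compounds:
compound 1, `CC(CCCCCCCCCCCCCCCCO[C@@H]1O[C@H](CO)[C@@H](O)[C@H](O)[C@@H]1O)C(=O)C1=C(O)N(C)C(C)C1=O`: 50500 nM
compound 2, `CC(=O)OC[C@H]1O[C@@H](OCCCCCCCCCCCCCCC(C)C(=O)C2=C(O)N(C)C(C)C2=O)[C@@H](O)[C@@H](O)[C@@H]1O`: 57200 nM

In an ADME assay on L929 cells (Mus musculus) for antiproliferative activity (on this read-out higher numbers stand for weaker inhibition of growth and lower numbers for stronger inhibition of growth), compound 1 gives 50500 nM, and in the same assay compound 2 gives 57200 nM. Among the measured compounds shown here, compound 2 holds the highest of the two numbers, yet its only neighbour, compound 1, lies within the usual scatter, so the two cannot be placed in any order of growth inhibition.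

Compound 3, `CC(CCCCCCCCCCCCCCO[C@@H]1O[C@H](CO)[C@@H](O)[C@H](O)[C@@H]1O)C(=O)C1=C(O)N(C)C(C)C1=O`, is reached from compound 2 by a single change: hydrogen in place of acetyl on an oxygen on a saturated carbon. For the measured compounds named here, no pair of measured compounds differing in one place exists, so there is no measured step to lean on. The expected step from compound 2 to compound 3 in this assay is a 1.1-fold lower number from compound 2 to compound 3 (0.06 log units; within the scatter), that is, none beyond the scatter. Compound 3 is therefore estimated at 50000 nM, with a range from 20000 nM to 125000 nM.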

Compound 3, concentration for 50% growth inhibition: > 90000 nM
Compound 3: no number, only a limit; the forecaster's own chance of this, stated with the estimate: 10%; middle value at least 1.8-fold (0.25 log units) away from the limit.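

In this assay compound 3 gives > 90000 nM, which is a limit of the assay and not a number. Among the compounds shown here, this provides the first measured single change, acetoxymethyl to hydroxymethyl, and it reads as an at least 1.5-fold higher number from compound 2 to compound 3 (0.19 log units; that floor lies within the scatter). Since the floor of that step lies within the scatter, the result does not establish that removing the acetyl from this oxygen weakens growth inhibition, and it only bounds the step from one side: the limit of > 90000 nM in this assay, at which 1 of the 3 values shown sits.

As far as these compounds go, the true size of the step remains open, as does whether it would hold on the other chain length, that of compound 1. Also open, from the compounds shown here alone, is how a benzoyl group on the same oxygen, or an amine in place of acetoxy, would read in this assay.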